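Amide variation on the methoxyphenoxy-acetanilide series

This account rests on a few compounds, and the source may have more. Where it says the series, first, only, none or still open, it means among the compounds named here.

Measured compounds in an assay on isolated protein for binding affinity to melatonin receptor type 1A (Homo sapiens); on this read-out lower numbers stand for stronger inhibition and higher numbers for weaker inhibition:
- compound 1 `COc1cccc(Oc2ccc(NC(C)=O)cc2)c1`: 84 nM
- compound 2 `CCC(=O)Nc1ccc(Oc2cccc(OC)c2)cc1`: 300 nM
- compound 3 `C/C=C/C(=O)Nc1ccc(Oc2cccc(OC)c2)cc1`: 98 nM

Compound 3 sits second highest of the three numbers; its nearest neighbour is compound 1, and the gap between them is within the scatter, while compound 2 stands furthest from it, a gap beyond the scatter.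

The next compound, compound 4 `COCC(=O)Nc1ccc(Oc2cccc(OC)c2)cc1`, is not yet measured. Its change from compound 3 reads (methoxymethyl in place of prop-1-en-1-yl on a carbonyl carbon).

For the measured compounds named here, two measured steps bear on this. Replacing ethyl by prop-1-en-1-yl gave a 3.1-fold lower number from compound 2 to compound 3 (0.49 log units; beyond the scatter), and extending the acetyl chain by one carbon gave a 3.6-fold higher number from compound 1 to compound 2 (0.55 log units; beyond the scatter). Methoxymethyl is, like ethyl, a saturated chain of three heavy atoms attached to the carbonyl carbon, whereas the unsaturated prop-1-en-1-yl chain is what separates compound 3 from compound 2. The step from compound 3 to compound 4 is therefore expected to run upward, toward the number of compound 2, roughly a 2.2-fold higher number from compound 3 to compound 4 (0.35 log units; beyond the scatter). The estimate for compound 4 in this assay is 220 nM, with a range from 80 nM to 600 nM, expected rather than known.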

Compound 4, inhibition constant: 180 nM
Compound 4: middle estimate off by 1.2-fold (0.09 log units), on the high side; the measured number falls inside the stated range.
By their numbers in this assay, from the lowest: compounds 1, 3, 4 and 2 (each within the scatter of the next, the first and the last beyond it).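

In this assay, methoxymethyl on the carbonyl carbon gives a 1.8-fold higher number from compound 3 to compound 4 (0.26 log units; within the scatter) and methoxy in place of methyl on the saturated chain carbon gives a 1.7-fold lower number from compound 2 to compound 4 (0.22 log units; within the scatter) so compound 4 lies within the scatter of both compound 2 and compound 3, although those two stand apart from each other. Methoxy in place of hydrogen on that same chain carbon gives a 2.1-fold higher number from compound 1 to compound 4 (0.33 log units; beyond the scatter) so compound 4 stays apart from the acetyl compound 1, as compound 2 does, while compound 3 does not. No measured evidence bears on what lies behind these steps.

On these data alone, whether a longer chain such as 2-methoxyethyl or an amine such as dimethylaminomethyl on the carbonyl carbon would fall within this same span remains open. Also open, as far as these compounds go, is whether a hydroxymethyl group would track with methoxymethyl at this position.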